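Moving the chlorine along the benzylsulfanyl arm

This account rests on a few compounds, and the source may have more. Where it says the series, first, only, none or still open, it means among the compounds named here.

Compound 3 `CC1=C(C(=O)Nc2ccc(F)cc2)C(c2ccc([N+](=O)[O-])cc2)N=C(SCc2ccccc2Cl)N1` gives 17.4% in a functional assay on the whole organism (artery, strain albino) with Rattus norvegicus as the target, with a stated time of 600 min, at a dose of 10 mg/kg by the oral route; a lower number here means less inhibition, a higher number more inhibition at the dose given (going by the name of the read-out). Compound 1 `COc1ccc(C2N=C(SCc3cccc(Cl)c3)NC(C)=C2C(=O)Nc2ccc(F)cc2)cc1OC` gives 17.4% in this assay, level with compound 3 at the digits reported, and the two together hold the lowest of the three numbers. For the measured compounds named here, compound 2 `CC1=C(C(=O)Nc2ccc(F)cc2)C(c2ccc([N+](=O)[O-])cc2)N=C(SCc2ccccc2)N1` gives 32.3%; the only measured single-point step, a number 14.9 percentage points lower from compound 2 to compound 3 (beyond the scatter), is a modest fall beyond the scatter and accounts for the gap between compound 2 and compound 3.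

Compound 4 `CC1=C(C(=O)Nc2ccc(F)cc2)C(c2ccc([N+](=O)[O-])cc2)N=C(SCc2cccc(Cl)c2)N1` differs from compound 3 only in 3-chlorophenyl in place of 2-chlorophenyl on a saturated chain carbon bound to a sulfur. Going by the values given here, no measured step covers this change: the one step on hand concerns adding chlorine, not moving it. Compound 1 carries the 3-chlorobenzyl group of compound 4 on a different aryl-bearing core, and its value and that of compound 3 show only that the two chlorine placements sit within the scatter of each other. For compound 4 the expected step of a number 1.6 percentage points higher from compound 3 to compound 4 (within the scatter) is therefore none beyond the scatter. Compound 4 is estimated at 19%, with a range from 8% to 32%.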

Compound 4, a percentage reported as inhibition, in the whole organism at one dose (the size of the read-out at that dose, not a potency): 16.4%
For compound 4 the middle estimate is 2.6 percentage points above the measured one; the measured number falls inside the stated range.
By their numbers in this assay, from the lowest: compounds 4, 1 and 3 (each within the scatter of the next); then compound 2.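

With the rest of the structure fixed, exchanging 2-chlorophenyl for 3-chlorophenyl on a saturated chain carbon bound to a sulfur gives a number 1 percentage points lower from compound 3 to compound 4 (within the scatter) in this assay, so these two chlorine placements are not separated in this series. The effect of adding chlorine to the benzyl arm is also no longer tied to one placement: a number 15.9 percentage points lower from compound 2 to compound 4 (beyond the scatter) stands with a number 14.9 percentage points lower from compound 2 to compound 3 (beyond the scatter), and both steps lie beyond the scatter. With 3-chlorobenzyl held constant, a number 1 percentage points lower from compound 1 to compound 4 (within the scatter) shows that 4-nitrophenyl and 3,4-dimethoxyphenyl on a saturated ring carbon are also not separated.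

Still open, from the compounds shown here alone, is whether a methoxy group or a carboxylic acid on the benzyl ring, or a longer chain in place of the benzyl group, would give a different number. Nothing available bears on what lies behind these numbers.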